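This account rests on a few compounds, and the source may have more. Where it says the series, first, only, none or still open, it means among the compounds named here.

Compounds measured so far:
compound 1 `Cc1cc(-c2c(O)nc3cc(Cl)c(C(=O)Nc4cnsn4)cc3c2OCCC2CC3CCN2CC3)cc(C)c1C` gives 0.6 nM in an assay on CHO cells for binding affinity to Gonadotropin-releasing hormone receptor (Homo sapiens), read by radioligand binding; on this read-out lower numbers stand for stronger inhibition and higher numbers for weaker inhibition; compound 2 `Cc1cc(-c2c(O)nc3cc(Cl)c(C(=O)Nc4cnsn4)cc3c2OCC[C@H]2CCO2)cc(C)c1C` gives 0.9 nM; compound 3 `Cc1cc(-c2c(O)nc3cc(Cl)c(C(=O)Nc4ccncn4)cc3c2OCC[C@@H]2CCCN2)cc(C)c1C` gives 0.8 nM.

Compound 2 lies within the usual scatter of both compound 1 and compound 3, so the three numbers cannot be told apart. Compound 4 `Cc1cc(-c2c(O)nc3cc(Cl)c(C(=O)Nc4cnsn4)cc3c2OCCC2COCCN2)cc(C)c1C` differs from compound 2 by morpholin-3-yl in place of oxetan-2-yl on a saturated chain carbon, two bonds along the chain from an oxygen on an aromatic ring. Among the measured compounds shown here, the one measured step that bears on this position, a 1.5-fold higher number from compound 1 to compound 2 (0.18 log units; within the scatter), shows that a large change at this chain carbon left the number where it was; compound 3, carrying a different nitrogen ring there, sits at the same level. No step beyond the scatter is therefore expected for compound 4, and its value in this assay is estimated at 0.7 nM (range 0.3 nM to 1.8 nM), a change of a 1.3-fold lower number from compound 2 to compound 4 (0.11 log units; within the scatter).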

Compound 4, half-maximal inhibitory concentration: 0.7 nM
Compound 4: the middle estimate sits on the measured number at the digits printed, and the stated range covers the measured number.
By their numbers in this assay, from the lowest: compounds 1, 4, 3 and 2 (each within the scatter of the next).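

In this assay the change shows as a 1.3-fold lower number from compound 2 to compound 4 (0.11 log units; within the scatter) and as a 1.2-fold higher number from compound 1 to compound 4 (0.07 log units; within the scatter) and so places a third group on this chain carbon within the scatter of the other two. Morpholin-3-yl, with its hydrogen-bond donor and two ring hetero atoms, thus joins oxetan-2-yl and the two-ring group of compound 1, with no step among the three beyond the scatter. Nothing available offers an explanation for this result. The compounds shown leave open whether a carboxylic acid or an open-chain amine on this chain carbon would stay at the same level, and whether a longer chain between the ring and the oxygen would.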